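Small Ether Change at the Assay Limit

A few compounds are considered here, and "the series" means these few. Any claim that something is new, unique, unknown or untested is made for them only; others in the source may bear on it.

Measured in a functional assay on HepG2 cells (Homo sapiens) for inhibition, read by MTT assay, with a stated time of 72 h; on this read-out lower numbers stand for stronger inhibition and higher numbers for weaker inhibition:
- Compound 1 `CC(C)(C)n1cc2c(n1)C(=O)CC1(CCN(C(=O)c3cc(-c4ccc(Br)cc4)nc4ccccc34)CC1)O2`: 820 nM
- Compound 2 `COc1cc(C(=O)N2CCC3(CC2)CC(=O)c2nn(C(C)(C)C)cc2O3)c2ccccc2n1`: > 10000 nM, a limit

Compound 2 stands at the limit of > 10000 nM in this assay, at which 1 of the 2 values shown sits, so its true value is not known. Compound 3 `CC(C)Oc1cc(C(=O)N2CCC3(CC2)CC(=O)c2nn(C(C)(C)C)cc2O3)c2ccccc2n1` differs from it in one place: isopropyl in place of methyl on an oxygen on an aromatic ring, with isopropyl in place of methyl on an oxygen on an aromatic ring. For the measured compounds named here, only one measured step bears on this. It is the large step of an at least 12-fold higher number from compound 1 to compound 2 (1.08 log units; beyond the scatter), where methoxy took the place of 4-bromophenyl on an aromatic carbon. That swap involves a much bigger group than the one changing here, so it gives only weak guidance. No clear step beyond the scatter is therefore expected in this assay, and neither direction is favoured. Compound 3 is expected at about 10000 nM, with an estimated range of 3000 nM to 30000 nM. The estimated step is a number no higher from compound 2 to compound 3 (the limit leaves the size open).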

Compound 3, half-maximal inhibitory concentration: 3150 nM
Estimate against measurement, compound 3: 3.2-fold (0.50 log units) above, and the stated range covers the measured number.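

In this assay, this position responds even to a small change in the group on the oxygen, with methoxy to isopropoxy giving an at least 3.1-fold lower number from compound 2 to compound 3 (0.50 log units; beyond the scatter). On these data alone, the true size of that step remains unknown, since the value for compound 2 is a limit and not a number: the limit of > 10000 nM in this assay, at which 1 of the 3 values shown sits. The isopropoxy group still does not match the 4-bromophenyl group on the same aromatic carbon, with a 3.8-fold higher number from compound 1 to compound 3 (0.58 log units; beyond the scatter).

The compounds shown leave open whether activity would keep changing in the same direction with a longer chain on the oxygen, such as butyl, or with a ring there, such as cyclopentyl. They also leave open how an amine in place of the ether oxygen would compare, since a single pair of ethers cannot establish a trend.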